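The source may report more compounds than this note shows. Statements on the series, on what has been measured and on what is new or still open speak of the compounds shown alone.

Compound 1 `CCOC(=O)CSCc1nc2cc([N+](=O)[O-])ccc2[nH]1` is measured in a functional assay on HepG2 cells (Homo sapiens) for cytotoxicity, read by MTT assay, with a stated time of 48 h (on this read-out lower numbers stand for stronger inhibition and higher numbers for weaker inhibition), only as a limit, > 100000 nM, sitting at the assay ceiling (the limit of > 100000 nM in this assay, at which 1 of the 2 values shown sits). For the measured compounds named here, compound 2 `N#CCSCc1nc2cc([N+](=O)[O-])ccc2[nH]1` gives 30600 nM in this assay, the only actual number so far. Going by the values given here, the step of an at least 3.2-fold lower number from compound 1 to compound 2 (0.51 log units; beyond the scatter) is the single measured change in the set, a swap at the saturated chain carbon bound to a sulfur. Compound 3 `NC(=S)NNC(=O)CSCc1nc2cc([N+](=O)[O-])ccc2[nH]1` is not yet measured; it differs from compound 2 by a group of 7 heavy atoms (2 carbon, 3 nitrogen, 1 oxygen, 1 sulfur; no ring) in place of a group of 2 heavy atoms (1 carbon, 1 nitrogen; no ring), on a saturated chain carbon bound to a sulfur. Among the compounds with values here, only the step from compound 1 to compound 2 touches this same position, and no measured step covers the group that enters, so the expectation rests on that step alone. For compound 3 the expected step is a 1.6-fold higher number from compound 2 to compound 3 (0.21 log units; within the scatter), a modest shift at most. The estimate for compound 3 in this assay is 50000 nM, with a range from 15000 nM to 150000 nM.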

Compound 3, half-maximal inhibitory concentration: 7050 nM
Compound 3: the middle estimate sits 7.1-fold (0.85 log units) above what was measured; measured number below the stated range.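

In this assay, cyano does not give the lowest number at the saturated chain carbon bound to a sulfur: the larger, ring-free group with 3 hydrogen-bond donors brings a 4.3-fold lower number from compound 2 to compound 3 (0.64 log units; beyond the scatter) and shows that this position accepts far more than 2 heavy atoms. A carbonyl can also stay in place, since the exchange on the carbonyl carbon gives an at least 14-fold lower number from compound 1 to compound 3 (1.15 log units; beyond the scatter) and the carbonyl alone therefore does not keep a compound at the ceiling. That second step is a bound and not a measured size, as compound 1 stands only as a limit: the limit of > 100000 nM in this assay, at which 1 of the 3 values shown sits.

The compounds shown leave open which part of the entering group carries the step, and whether a simple amide or a carboxylic acid on the same carbon would stand nearer compound 2 or compound 3. On these data alone, a longer chain between the sulfur and the carbonyl also remains open.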